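This account rests on a few compounds, and the source may have more. Where it says the series, first, only, none or still open, it means among the compounds named here.

Compound 1, `CC(C)(N)C(=O)N[C@H](COCc1ccccc1Cl)c1nnnn1CCOC(=O)NCCCCO`, in a functional assay on cells for inhibition of growth hormone secretagogue receptor type 1 (Homo sapiens), read by FLIPR and calcium flux (a higher number here means that more compound is needed for the effect, a lower number that less compound is needed), gives 0.45 nM.
Compound 2, `CC(C)(N)C(=O)N[C@H](COCc1cccc(Cl)c1)c1nnnn1CCOC(=O)NCCCCO`, in this assay gives 1.6 nM.
Compound 3, `CC(C)(N)C(=O)N[C@H](COCc1cccc(Cl)c1Cl)c1nnnn1CCOC(=O)NCCCCO`, in this assay gives 0.61 nM.

Among these three, compound 3 stands at the second highest number. Its nearest neighbour is compound 1, and the step of a 1.4-fold higher number from compound 1 to compound 3 (0.13 log units; within the scatter) lies within the scatter, so the two cannot be placed in order. Its furthest neighbour is compound 2, separated by a 2.6-fold lower number from compound 2 to compound 3 (0.42 log units; beyond the scatter), a modest step beyond the scatter.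

Compound 4, `CC(C)(N)C(=O)N[C@H](COCc1cccc(C(F)(F)F)c1)c1nnnn1CCOC(=O)NCCCCO`, has not yet been measured. It differs from compound 3 in that (3-(trifluoromethyl)phenyl in place of 2,3-dichlorophenyl on a saturated chain carbon bound to an oxygen on a saturated carbon).

Among the measured compounds shown here, two measured steps bear on this change. The step of a 3.6-fold higher number from compound 1 to compound 2 (0.55 log units; beyond the scatter) shows that the move from a 2-chlorophenyl to a 3-chlorophenyl raised the number modestly, and the step of a 2.6-fold lower number from compound 2 to compound 3 (0.42 log units; beyond the scatter) shows that adding the second chloro to give the 2,3-dichlorophenyl lowered it again. Read in reverse, that second step suggests a modest rise when the 2,3-dichlorophenyl gives way to a ring carrying only a substituent in the 3-position. For the measured compounds named here, no measured compound carries a trifluoromethyl group, so nothing is known about that group's own contribution; the expectation therefore rests on the chloro-bearing compounds alone.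

Compound 4 is estimated to show a modest rise in number, a 3.0-fold higher number from compound 3 to compound 4 (0.47 log units; beyond the scatter), landing near the value of compound 2. The estimate for compound 4 is 1.8 nM, with a range from 0.6 nM to 5.5 nM.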

Compound 4, half-maximal effective concentration: 1.79 nM
Beside the measured number, compound 4's estimate is 1.0-fold (0.00 log units) above it; the range from low to high includes it.
By their numbers in this assay, from the lowest: compounds 1 and 3 (each within the scatter of the next); then compounds 2 and 4 (each within the scatter of the next).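

In this assay, among the compounds shown here, the step of a 1.1-fold higher number from compound 2 to compound 4 (0.05 log units; within the scatter) shows that at this position, on a ring otherwise unchanged, trifluoromethyl and chloro cannot be told apart, a comparison that the earlier compounds, all carrying only chloro, could not offer. The steps of a 2.9-fold higher number from compound 3 to compound 4 (0.47 log units; beyond the scatter) and a 4.0-fold higher number from compound 1 to compound 4 (0.60 log units; beyond the scatter) are both modest and beyond the scatter, and they extend the earlier split to a group other than chloro: compounds 1 and 3, with the 2-chlorophenyl and 2,3-dichlorophenyl rings, hold the lower numbers, while compounds 2 and 4, with the 3-chlorophenyl and 3-(trifluoromethyl)phenyl rings, hold the higher ones, and none of the four goes against this split. Nothing in the data at hand accounts for either the match between the two groups or the split among the rings.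

As far as these compounds go, whether a nitrile, a methoxy group or a bromo on the same aromatic carbon would also stay within the scatter of compounds 2 and 4 remains open. From the compounds shown here alone, all four compounds also share the same core and the same chain ending in a hydroxyl, so what an amine or a carboxylic acid at that chain end would do remains unknown.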